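Pentyl on the Phenyl Ring: Expected Cytotoxicity of Compound 4

This account rests on a few compounds, and the source may have more. Where it says the series, first, only, none or still open, it means among the compounds named here.

Compound 1 `O=C1c2nccnc2C(=O)N1c1ccccc1` gives 71000 nM in an ADME assay on Vero cells (Chlorocebus sabaeus) for cytotoxicity; on this read-out higher numbers stand for weaker inhibition and lower numbers for stronger inhibition.
Compound 2 `O=C1c2cccnc2C(=O)N1c1ccc(Cl)cc1` gives 92000 nM in this assay.
Compound 3 `COc1ccc(CN2C(=O)c3nccnc3C2=O)cc1OC` reaches only the assay limit of > 100000 nM in this assay, so its number is not known.

Of the two measured numbers, the values of compound 1 and compound 2 sit within the scatter of each other, so neither can be called more or less toxic than the other. The value of compound 3 is a limit, not a number (the limit of > 100000 nM in this assay, at which 1 of the 3 values shown sits). Within the data shown here, no two of these measured compounds differ in only one place, so no single step in this assay has yet been measured.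

Compound 4 `CCCCCc1ccc(N2C(=O)c3nccnc3C2=O)cc1` is obtained from compound 1 by a single change: pentyl in place of hydrogen on an aromatic carbon. The pentyl chain carries no ring, no donor or acceptor and no charge.

Among the measured compounds shown here, with no measured step of this kind to lean on, only a cautious expectation is possible. The step from compound 1 to compound 4 is expected to be small and, if anything, to lower the number, a 1.6-fold lower number from compound 1 to compound 4 (0.20 log units; within the scatter). For compound 4 the estimate in this assay is therefore 45000 nM, expected to lie between 15000 nM and 100000 nM, with a fair chance that only a limit is reported.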

Compound 4, half-maximal inhibitory concentration: 16000 nM
For compound 4 the middle estimate is 2.8-fold (0.45 log units) above the measured one; measured number inside the range.
By their numbers in this assay, from the lowest: compound 4; then compounds 1 and 2 (each within the scatter of the next). At a limit, above all of these: compound 3.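

Hydrogen to pentyl on an aromatic carbon, para to a large group, provides the first single change that can be read in this assay: a 4.4-fold lower number from compound 1 to compound 4 (0.65 log units; beyond the scatter). This position on the six-membered aromatic ring of carbon only is therefore one at which the read-out responds to substitution, and with pentyl the response runs towards stronger inhibition, that is, towards greater cytotoxicity to the Vero cells. The only limit among the compounds shown belongs to compound 3, and it is a limit rather than a number: the limit of > 100000 nM in this assay, at which 1 of the 4 values shown sits.

On these data alone, a single step with pentyl cannot show whether the size of the change follows chain length, and so the effect of a shorter chain such as ethyl or a longer chain such as octyl at the same place remains open. As far as these compounds go, it is equally open whether an amine or a carboxylic acid on this aromatic carbon would shift the number in the same direction, or whether the step seen with pentyl would carry over to a different core.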